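Morpholin-4-yl gives way to (1-phenylethyl)amino in a flat series

A few compounds are considered here, and "the series" means these few. Any claim that something is new, unique, unknown or untested is made for them only; others in the source may bear on it.

In a functional assay on MCF7 cells (Homo sapiens) for antiproliferative activity, read by MTT assay, with a stated time of 24 h (on this read-out lower numbers stand for stronger inhibition and higher numbers for weaker inhibition), three compounds built on the shared core have been measured so far. Compound 1 (`CCCCc1oc2ccccc2c1C(=O)c1ccc(OCC(=O)N2CCCC2)cc1`) gives 42400 nM, compound 2 (`CCCCc1oc2ccccc2c1C(=O)c1ccc(OCC(=O)Nc2cccc(OC)c2)cc1`) gives 38500 nM and compound 3 (`CCCCc1oc2ccccc2c1C(=O)c1ccc(OCCCC(=O)N2CCOCC2)cc1`) gives 41200 nM in the same test. The steps that reach compound 3 read a 1.0-fold lower number from compound 1 to compound 3 (0.01 log units; within the scatter) and a 1.1-fold higher number from compound 2 to compound 3 (0.03 log units; within the scatter) and both stay within the scatter. Compound 3 therefore stands level with the other two.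

Compound 4 (`CCCCc1oc2ccccc2c1C(=O)c1ccc(OCCCC(=O)N[C@H](C)c2ccccc2)cc1`) carries (1-phenylethyl)amino in place of morpholin-4-yl on a carbonyl carbon. The nearest measured exchange put (3-methoxyphenyl)amino in place of pyrrolidin-1-yl on a carbonyl carbon, and that step, a 1.1-fold lower number from compound 1 to compound 2 (0.04 log units; within the scatter), also stayed within the scatter. None of the three measured steps leaves the scatter, so no larger move is expected here. The estimated step is a 1.2-fold lower number from compound 3 to compound 4 (0.07 log units; within the scatter) and it is expected to remain within the scatter. For compound 4 the expected value in this assay is 35000 nM with an estimated range of 18000 nM to 60000 nM around it.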

Compound 4, half-maximal inhibitory concentration: > 50000 nM
Compound 4 was reported as a limit; the forecaster's own chance of this, stated with the estimate: 8%; middle value at least 1.4-fold (0.15 log units) from the limit.
By their numbers in this assay, from the lowest: compounds 2, 3 and 1 (each within the scatter of the next). At a limit, above all of these: compound 4.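

In this assay, for the compounds shown here, compound 4 is reported only as a limit, > 50000 nM, the first reading of the series that is not a number. The step is an at least 1.2-fold higher number from compound 3 to compound 4 (0.08 log units; that floor lies within the scatter), so the exchange of morpholin-4-yl for (1-phenylethyl)amino on this carbonyl carbon brought no stronger inhibition, but because only its floor is known, its true size stays undetermined and it may or may not lie beyond the scatter. The whole reading of this change rests on one entry: the limit of > 50000 nM in this assay, at which 1 of the 4 values shown sits.

The compounds shown leave open how far compound 4 lies past that limit, and whether the opposite stereoisomer or a benzylamino group without the methyl would return a number. They also leave open whether a carboxylic acid or a primary amide at this carbonyl carbon would move the read-out beyond the scatter.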